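A Methoxy Group Added to an Inactive Triazole Series

This account rests on a few compounds, and the source may have more. Where it says the series, first, only, none or still open, it means among the compounds named here.

Compound 1 `Cc1c(O)ccc2c1[C@H](Cn1cc(-c3ccccc3)nn1)[C@@]13CC(=O)[C@@](C)(CC[C@@H]21)C3` was tested in a functional assay on MCF7 cells (Homo sapiens) for cytotoxicity, read by MTT assay, with a stated time of 4 days; on this read-out lower numbers stand for stronger inhibition and higher numbers for weaker inhibition. In this assay compound 1 gives > 20000 nM, which is a limit of the assay rather than a number. Two companions share this outcome. Compound 2 `C=C1C[C@]23C[C@@]1(O)CC[C@H]2c1ccc(OS(=O)(=O)c2ccc(C)cc2)c(C)c1[C@@H]3Cn1cc(-c2ccc(Cl)cc2)nn1` in this assay gives > 20000 nM, again a limit. Compound 3 `C=C1C[C@]23C[C@@]1(O)CC[C@@H]2c1cccc(C)c1[C@@H]3Cn1cc(-c2ccccc2)nn1` in this assay gives > 20000 nM, also a limit. Compound 1 therefore stands at the limit of > 20000 nM in this assay, at which 3 of the 3 values shown sit, and no ordering among the three compounds can be drawn from these results.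

Compound 4 `COc1ccc(-c2cn(C[C@H]3c4c(ccc(O)c4C)[C@@H]4CC[C@@]5(C)C[C@]43CC5=O)nn2)cc1` has not yet been tested. It differs from compound 1 by methoxy in place of hydrogen on an aromatic carbon. Going by the values given here, no measured pair among the compounds above isolates this change. The step is expected to be a step that the limit leaves unreadable from compound 1 to compound 4, none beyond the scatter, and the outcome for compound 4 is expected most likely to remain a limit of the assay. The estimate for compound 4 in this assay is 25000 nM, with an expected range from 8000 nM to 80000 nM.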

Compound 4, half-maximal inhibitory concentration: > 20000 nM
Compound 4 was reported as a limit; the forecaster's own chance of this, stated with the estimate: 80%; the middle value does not contradict the limit.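

In this assay compound 4 gives > 20000 nM, which is a limit of the assay and not a number. Going by these compounds alone, compound 1 also sits at a limit, so no step between compound 1 and compound 4 can be read. The compounds shown leave open whether methoxy has any effect on cytotoxicity, because all of them share one result: the limit of > 20000 nM in this assay, at which 4 of the 4 values shown sit.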